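The compounds below may be only part of what the source reports. "The series", "measured", "known", "first", "only" and "open" are said of these compounds alone.

Compound 1 `C#Cc1cccc(Nc2ncnc3cc(OCCCCCn4ccnc4[N+](=O)[O-])c(OC)cc23)c1` is a quinazoline-type kinase inhibitor carrying a nitroimidazole on a chain; in a functional assay on HT-29 cells (Homo sapiens) for inhibition, read by sulforhodamine B assay, with a stated time of 72 h (on this read-out lower numbers stand for stronger inhibition and higher numbers for weaker inhibition), compound 1 gives 280 nM. Compound 2 `C#Cc1cccc(Nc2ncnc3cc(OCCOCCn4ccnc4[N+](=O)[O-])c(OC)cc23)c1` differs by 2-(2-nitro-1H-imidazol-1-yl)ethoxy in place of 3-(2-nitro-1H-imidazol-1-yl)propyl on a saturated chain carbon, two bonds along the chain from an oxygen on an aromatic ring, and in this assay compound 2 gives 6040 nM, so that a 22-fold higher number from compound 1 to compound 2 (1.33 log units; beyond the scatter). Compound 3 `COc1cc2c(Nc3cccc(Br)c3)ncnc2cc1OCCCCCn1ccnc1[N+](=O)[O-]` differs from compound 1 by bromo in place of ethynyl on an aromatic carbon; in this assay compound 3 gives 2540 nM, and a 9.1-fold higher number from compound 1 to compound 3 (0.96 log units; beyond the scatter). Compound 4 `COc1cc2c(Nc3cccc(Br)c3)ncnc2cc1OCCOCCn1ccnc1[N+](=O)[O-]` has not yet been measured; it differs from compound 3 by 2-(2-nitro-1H-imidazol-1-yl)ethoxy in place of 3-(2-nitro-1H-imidazol-1-yl)propyl on a saturated chain carbon, two bonds along the chain from an oxygen on an aromatic ring, the same change, at the same place, as that from compound 1 to compound 2. The step is expected to be a 16-fold higher number from compound 3 to compound 4 (1.20 log units; beyond the scatter), resting on the step of a 22-fold higher number from compound 1 to compound 2 (1.33 log units; beyond the scatter) but allowed to be somewhat smaller, since compound 3 already starts weaker. Compound 4 is therefore estimated at 40000 nM, plausibly between 12000 nM and 120000 nM.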

Compound 4, half-maximal inhibitory concentration: 3440 nM
Estimate against measurement, compound 4: 12-fold (1.07 log units) above; measured number below the stated range.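

In this assay, carrying the chain change onto the bromo compounds gives only a 1.4-fold higher number from compound 3 to compound 4 (0.13 log units; within the scatter), so the large step seen with the ethynyl compounds does not carry over: the same change on two cores in this assay, a 22-fold higher number (1.33 log units; beyond the scatter) from compound 1 to compound 2 and a 1.4-fold higher number (0.13 log units; within the scatter) from compound 3 to compound 4, 16-fold (1.20 log units) apart, beyond the scatter of two such steps. Read the other way, bromo in place of ethynyl gives a 1.8-fold lower number from compound 2 to compound 4 (0.24 log units; within the scatter) when the 2-(2-nitro-1H-imidazol-1-yl)ethoxy chain is present, unlike its step with the 3-(2-nitro-1H-imidazol-1-yl)propyl chain: the same change on two cores in this assay, a 9.1-fold higher number (0.96 log units; beyond the scatter) from compound 1 to compound 3 and a 1.8-fold lower number (0.24 log units; within the scatter) from compound 2 to compound 4, 16-fold (1.20 log units) apart, beyond the scatter of two such steps. In these four compounds the two changes therefore do not act independently, so a step measured on one core cannot simply be transferred to the other, but the numbers do not show why.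

As far as these compounds go, it remains open whether this dependence also appears with chloro or a nitrile in place of bromo, or with a longer chain. From the compounds shown here alone, whether an amine such as morpholine at the chain end would behave like the nitroimidazole is also open.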